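Nitrooxy in place of bromo on a chalcone amide

The source may hold more compounds than are shown below. What is called first, only, known or untested is meant among the compounds shown, and "the series" means these compounds.

The study concerns two measured compounds and one awaiting its number in a functional assay on the whole organism (strain albino) for inhibition, with Rattus norvegicus as the target, read by paw edema, with stated times of 30 min and 5 h, at a dose of 100 mg/kg by the oral route; on this read-out lower numbers stand for less inhibition and higher numbers for more inhibition at the one dose given (going by the name of the read-out). Compound 1, `COc1ccc(/C=C/C(=O)c2ccc(NC(=O)CBr)cc2)cc1`, gives 34% in this assay. Compound 2, `O=C(CBr)Nc1ccc(C(=O)/C=C/c2ccco2)cc1`, gives 25% in this assay. Among the compounds with values here, with only two numbers in hand, compound 2 and compound 1 cannot be told apart, since the gap between them lies within the usual scatter of such measurements; no step between measured compounds differing in a single place is available.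

Compound 3, `O=C(CO[N+](=O)[O-])Nc1ccc(C(=O)/C=C/c2ccco2)cc1`, differs from compound 2 as follows: nitrooxy in place of bromo on a saturated chain carbon bound to a carbonyl carbon. Within the data shown here, nothing among the measured compounds speaks to this change, so the expectation rests on the structural change alone. The account expects the step from compound 2 to compound 3 to be a number 5 percentage points higher from compound 2 to compound 3 (within the scatter), that is, no change beyond the scatter, with a slight lean toward more inhibition. On that basis compound 3 is estimated to give 30% in this assay, within a range from 15% to 48%.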

Compound 3, a percentage reported as inhibition, in the whole organism at one dose (the size of the read-out at that dose, not a potency): 39%
Beside the measured number, compound 3's estimate is 9 percentage points below it; low and high end bracket the measured number.
By their numbers in this assay, from the lowest: compounds 2, 1 and 3 (each within the scatter of the next, the first and the last beyond it).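

Within the data shown here, replacing bromo with nitrooxy on a saturated chain carbon bound to a carbonyl carbon gives, in this assay, a number 14 percentage points higher from compound 2 to compound 3 (beyond the scatter), a modest step and the first comparison here between compounds that differ in one place. With the rest of the structure unchanged, it shows that bromo is not required at this position for inhibition at the one dose given, and that the exchange for nitrooxy separates the pair by more than the scatter. No measurement at hand accounts for the step, so the data record the change in the read-out without explaining it.

The compounds shown leave open whether the same exchange would have a similar effect on the core of compound 1, which appears here only in its bromo form. Going by these compounds, it also remains unknown how an amine, a hydroxyl or a chloro at this place, or a longer chain carrying the nitrooxy, would read in this assay, so the step cannot yet be placed within a wider trend.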